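This account rests on a few compounds, and the source may have more. Where it says the series, first, only, none or still open, it means among the compounds named here.

Measured compounds:
- compound 1, `CC(C)(C)CCNC1C(=O)C(=O)/C1=C\c1ccc(C#N)cc1`: 2940 nM
- compound 3, `C[C@H](CC(C)(C)C)Nc1c(Nc2ccc(C#N)cc2)c(=O)c1=O`: 370 nM
- compound 2, `CCC(C)(C)/N=c1/c(-c2ccc(C(=O)CCc3ccccc3)cc2)c(O)c1=O`: no result reported

In a functional assay for inhibition, with Rattus norvegicus as the target (on this read-out lower numbers stand for stronger inhibition and higher numbers for weaker inhibition), compound 3 gives 370 nM, the lowest of the two numbers in hand. Its nearest neighbour is compound 1, whose value in this assay is higher by a margin that lies beyond the usual scatter. Compound 2 has no number to compare.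

Compound 4, `CCc1cc(C#N)ccc1Nc1c(N[C@H](C)CC(C)(C)C)c(=O)c1=O`, is not yet measured. It differs from compound 3 in one place: ethyl in place of hydrogen on an aromatic carbon. Going by the values given here, no pair of measured compounds shows what such a change does, so the step is expected to be small, in either direction or none beyond the scatter; the expected step from compound 3 to compound 4 is a 1.1-fold higher number from compound 3 to compound 4 (0.03 log units; within the scatter). For compound 4 in this assay the estimate is 400 nM, with a range from 120 nM to 1500 nM.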

Compound 4, half-maximal inhibitory concentration: 90 nM
Compound 4: the middle estimate sits 4.4-fold (0.65 log units) above what was measured, outside the stated range (below it).
By their numbers in this assay, from the lowest: compound 4; then compound 3; then compound 1.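

In this assay, going by these compounds alone, ethyl in place of hydrogen on this aromatic carbon gives a 4.1-fold lower number from compound 3 to compound 4 (0.61 log units; beyond the scatter) and so makes the number lower, the first sign that a change at this position can matter. Before this, no pair of compounds showed what a change here does. Nothing available explains why the number falls. From the compounds shown here alone, whether methyl, a longer chain or an amine at this same carbon would push the number lower still remains open. A single step also leaves open whether ethyl would act alike on the other aromatic carbons.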